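Series notes: acyl variation on the trimethoxyphenyl amide

The source may hold more compounds than are shown below. What is called first, only, known or untested is meant among the compounds shown, and "the series" means these compounds.

Compound 2 `CCC/C=C/C(=O)N(Cc1ccc(OC)c(O)c1)c1cc(OC)c(OC)c(OC)c1` holds the lowest number of the three measured compounds in a functional assay on MGC-803 cells (Homo sapiens) for inhibition, read by MTT assay, with a stated time of 48 h (on this read-out higher numbers stand for weaker inhibition and lower numbers for stronger inhibition), giving 70 nM. Compound 3 `COc1ccc(CNc2cc(OC)c(OC)c(OC)c2)cc1` gives 11400 nM and compound 1 `C/C=C/C(=O)N(Cc1cccc(O)c1)c1cc(OC)c(OC)c(OC)c1` gives 14100 nM, both well beyond the scatter from compound 2. Among the measured compounds shown here, neither pair differs in one place, so no single step is known. Compound 4 `COc1ccc(CN(C(=O)CBr)c2cc(OC)c(OC)c(OC)c2)cc1O` is compound 2 with the acyl group exchanged: bromomethyl in place of pent-1-en-1-yl on a carbonyl carbon. Compound 1, which carries a shorter unsaturated acyl chain on a different benzyl group, is weak, but that involves two changes at once and gives no direct guide. The change is expected to cost some potency, with a 3.6-fold higher number from compound 2 to compound 4 (0.55 log units; beyond the scatter) as a step of moderate size. Compound 4 is therefore estimated at 250 nM, within 40 nM to 2500 nM.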

Compound 4, half-maximal inhibitory concentration: 140 nM
Compound 4: middle estimate off by 1.8-fold (0.25 log units), on the high side; the measured number falls inside the stated range.
By their numbers in this assay, from the lowest: compounds 2 and 4 (each within the scatter of the next); then compounds 3 and 1 (each within the scatter of the next).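

Exchanging pent-1-en-1-yl for bromomethyl on a carbonyl carbon gives a 2.0-fold higher number from compound 2 to compound 4 (0.30 log units; within the scatter) in this assay, so the two acyl groups cannot be told apart in this read-out. With the benzyl group shared by these two compounds, this position therefore accepts an acyl group without a double bond and still keeps the number in the same range. No measured evidence bears on why the two groups read alike.

Open, on these data alone, is how a chloromethyl or a saturated pentyl group on this carbonyl carbon would read. Also open, as far as these compounds go, is whether the bromine itself matters, or whether any short acyl group would serve.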